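Hydroxyphenyl ketone replaces thiophene ketone in a triazolothiadiazine series

A few compounds are considered here, and "the series" means these few. Any claim that something is new, unique, unknown or untested is made for them only; others in the source may bear on it.

The measured compounds and their values in a functional assay on PC-3 cells (Homo sapiens) for cytotoxicity, read by MTT assay, with a stated time of 48 h (a higher number here means a weaker inhibitor, a lower number a stronger inhibitor), are:
compound 1 `COc1cc(-c2nnc3n2NC(c2ccco2)C(C(=O)c2cccs2)S3)cc(OC)c1OC`, 46200 nM
compound 2 `COc1cc(-c2nnc3n2NC(c2cccs2)C(C(=O)c2ccccc2)S3)cc(OC)c1OC`, 86300 nM
compound 3 `COc1ccc(C(=O)C2Sc3nnc(-c4cc(OC)c(OC)c(OC)c4)n3NC2c2cccs2)cc1`, 95900 nM

Compound 1 gives the lowest of the three numbers in this assay. Its nearest neighbour is compound 2, whose number lies within the scatter of that of compound 1, while the number of compound 3 lies beyond it. For the measured compounds named here, the only single-point step among the measured compounds is a 1.1-fold higher number from compound 2 to compound 3 (0.05 log units; within the scatter), a change on the aryl ketone that left the read-out essentially where it was.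

Compound 4 `COc1cc(-c2nnc3n2NC(c2ccco2)C(C(=O)c2ccc(O)cc2)S3)cc(OC)c1OC` follows from compound 1 by 4-hydroxyphenyl in place of thiophen-2-yl on a carbonyl carbon. Going by the values given here, no measured step covers this exchange. Compounds 1 and 2 differ in two places at once, so their values, which lie within the scatter of each other, only show that changes in this region of the shared core have not moved the read-out much. The step from compound 2 to compound 3 points the same way.

Compound 4 is therefore expected to stay close to compound 1, with a step of a 1.2-fold higher number from compound 1 to compound 4 (0.08 log units; within the scatter) that is not expected to exceed the scatter. In this assay the value of compound 4 is estimated at 55000 nM, within a range of 25000 nM to 120000 nM.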

Compound 4, half-maximal inhibitory concentration: 38300 nM
For compound 4 the middle estimate is 1.4-fold (0.16 log units) above the measured one; the range from low to high includes it.
By their numbers in this assay, from the lowest: compounds 4, 1, 2 and 3 (each within the scatter of the next, the first and the last beyond it).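

In this assay, for the compounds shown here, the exchange on the carbonyl carbon gives a 1.2-fold lower number from compound 1 to compound 4 (0.08 log units; within the scatter) and so provides the first reading at this position in which the rest of compound 1 stays unchanged, which the two-place difference between compound 1 and compound 2 could not provide. Here a five-membered aromatic ring with 1 hetero atom and 0 hydrogen-bond donors gives way to a six-membered aromatic ring of carbon only with 1 hydrogen-bond donor, a wider exchange than the methoxy step on the aryl ketone, yet the read-out of the two compounds cannot be told apart. No measurement at hand offers an explanation for this outcome.

The compounds shown hold no pair that separates the exchange of the ring from the hydroxyl on it, so the share of each in this result stays open. Going by these compounds, it also remains open whether an amine or a carboxylic acid on the aryl ring, or a longer alkyl chain in place of that ring on the carbonyl carbon, would give a step beyond the scatter.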